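Swapping thiophen-2-yl for furan-3-yl

The source may report more compounds than this note shows. Statements on the series, on what has been measured and on what is new or still open speak of the compounds shown alone.

The compounds here were tested in a functional assay on A549 cells (Homo sapiens) for cytotoxicity, read by MTT assay, with a stated time of 68 h; a higher number here means a weaker inhibitor, a lower number a stronger inhibitor. Compound 1 `O=C(Nc1cccc(-c2ccccn2)c1)C(Cl)Cl` gives only a limit, > 50000 nM. Compound 2 `O=C(Nc1cccc(-c2cccs2)c1)C(Cl)Cl` gives 47600 nM, the higher of the two actual numbers in this assay. The other number belongs to compound 3 `Cc1cccc(-c2cccc(NC(=O)C(Cl)Cl)c2)c1`, which gives a lower 8700 nM.

Compound 4 `O=C(Nc1cccc(-c2ccoc2)c1)C(Cl)Cl` departs from compound 2 by a single change, furan-3-yl in place of thiophen-2-yl on an aromatic carbon. For the measured compounds named here, only one measured step exchanges one such ring for another. That step, an at least 1.0-fold lower number from compound 1 to compound 2 (0.02 log units; that floor lies within the scatter), is a floor that lies within the scatter, and it involves a different pair of rings, so it offers no firm guide to direction. No shift beyond the scatter is therefore expected. The expected change, a 1.2-fold lower number from compound 2 to compound 4 (0.08 log units; within the scatter), is an estimate that stays within the scatter. Compound 4 is estimated at 40000 nM, with an expected range of 18000 nM to 70000 nM.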

Compound 4, half-maximal inhibitory concentration: 8480 nM
Beside the measured number, compound 4's estimate is 4.7-fold (0.67 log units) above it, outside the stated range (below it).
By their numbers in this assay, from the lowest: compounds 4 and 3 (each within the scatter of the next); then compound 2. At a limit, above all of these: compound 1.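

In this assay, exchanging thiophen-2-yl for furan-3-yl gives a 5.6-fold lower number from compound 2 to compound 4 (0.75 log units; beyond the scatter), so this place on the shared core responds to the identity of the ring even though both groups are five-membered aromatic rings with the same counted features. Measured against pyridin-2-yl, the same furan-3-yl group gives an at least 5.8-fold lower number from compound 1 to compound 4 (0.77 log units; beyond the scatter). Compound 1 gives only a limit, so that second step is a floor: the limit of > 50000 nM in this assay, at which 1 of the 4 values shown sits.

The compounds shown leave open whether the lower number follows the oxygen or the point of attachment, as the change from thiophen-2-yl to furan-3-yl alters both at once. Also open, on these data alone, is how furan-2-yl or thiophen-3-yl would read at this place, and what an amine on the five-membered ring would do.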